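The compounds below may be only part of what the source reports. "The series", "measured", "known", "first", "only" and "open" are said of these compounds alone.

Measured compounds:
- compound 1, `Nc1scc(CN2CCN(c3ccccc3C(F)(F)F)CC2)c1C(=O)c1ccc(Cl)cc1`: 0%
- compound 2, `Nc1scc(CN2CCN(c3cccc(F)c3F)CC2)c1C(=O)c1ccc(Cl)cc1`: 0%

Both compounds share one core and differ only in the aryl group on the amine nitrogen of the six-membered ring. In an assay on CHO cells for displacement of a labelled ligand from adenosine receptor A1 (Homo sapiens), read by scintillation counting, with a stated time of 120 min, tested at 10 uM (on this read-out higher numbers stand for more inhibition at the one concentration tested (going by the name of the read-out) and lower numbers for less inhibition), compound 1 gives 0%, and in this assay compound 2 gives 0%. For the measured compounds named here, the one step between them, no change at the digits printed from compound 1 to compound 2 (within the scatter), shows that exchanging one substituted phenyl for another on that ring nitrogen left the read-out where it was. Compound 2 therefore stands level with compound 1, with no separation between the two at the digits shown.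

Compound 3, `Nc1scc(CN2CCN(c3cc(Cl)ccc3Cl)CC2)c1C(=O)c1ccc(Cl)cc1`, has not yet been measured. It differs from compound 2 by 2,5-dichlorophenyl in place of 2,3-difluorophenyl on an amine nitrogen in a ring. Going by the values given here, the only measured step that bears on this change is the one from compound 1 to compound 2, which was flat. Among the compounds with values here, with one flat step on the same position as the sole guide, compound 3 is expected to show a step of a number 2 percentage points higher from compound 2 to compound 3 (within the scatter), that is none beyond the scatter. Compound 3 is thus estimated at 2%, within a range from -8% to 15%.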

Compound 3, a percentage reported as inhibition, at one concentration (the size of the read-out at that concentration, not a potency): 0%
Compound 3: the middle estimate sits 2 percentage points above what was measured; the range from low to high includes it.
By their numbers in this assay, from the lowest: compounds 1, 2 and 3 (each within the scatter of the next).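

The change from 2,3-difluorophenyl to 2,5-dichlorophenyl on the amine nitrogen in a ring gave no change at the digits printed from compound 2 to compound 3 (within the scatter) in this assay, and the change from 2-(trifluoromethyl)phenyl to 2,5-dichlorophenyl gave no change at the digits printed from compound 1 to compound 3 (within the scatter). The earlier pair covered only fluorine-bearing phenyl groups, whereas this result adds a phenyl group bearing chlorine and so extends the flat read-out at this position to three differently substituted phenyl groups. No evidence is available that would account for this lack of separation.

All three compounds read the same, so the series gives no direction for substitution at this position and does not show whether any group there could raise the inhibition in this assay. On these data alone, it remains open whether a phenyl group carrying a methoxy group, an amine or a carboxylic acid, or a longer chain in place of the phenyl group on that ring nitrogen, would move the read-out, and whether a change elsewhere on the shared core would do so.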